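From isopropyl to ethyl: what compound 3 may show

This account rests on a few compounds, and the source may have more. Where it says the series, first, only, none or still open, it means among the compounds named here.

Among the measured compounds shown here, in an ADME assay on microsomes from liver (Rattus norvegicus) for metabolic stability, read by LC-MS, using NADPH, with a stated time of 30 min, tested at 1 uM (a higher number here means faster removal of the compound, a lower number slower removal), compound 2 (`Cc1cc([C@H](C)Nc2nccc(N3C(=O)OC[C@@H]3C(C)C)n2)ncc1-c1ccnc(C(F)(F)F)c1`) gives 125 mL.min-1.g-1, the higher of the two numbers so far, while compound 1 (`Cc1cc([C@H](C)Nc2nccc(N3C(=O)OC[C@@H]3C)n2)ncc1-c1ccnc(C(F)(F)F)c1`) gives 36 mL.min-1.g-1. Compound 3 (`CC[C@H]1COC(=O)N1c1ccnc(N[C@@H](C)c2cc(C)c(-c3ccnc(C(F)(F)F)c3)cn2)n1`) differs from compound 2 in one place, hydrogen in place of methyl on a saturated chain carbon bound to a saturated chain carbon and a saturated ring carbon, which turns isopropyl into ethyl. For the measured compounds named here, only one measured step bears on this, a 3.5-fold higher number from compound 1 to compound 2 (0.54 log units; beyond the scatter), for isopropyl in place of methyl on a saturated ring carbon. Ethyl is intermediate among these groups, so part of that step is expected to reverse, though a single step cannot show a trend. The expected change is a 1.9-fold lower number from compound 2 to compound 3 (0.28 log units; within the scatter), downward but near the edge of the usual scatter. For compound 3 the estimated value is 65 mL.min-1.g-1, with a range from 38 mL.min-1.g-1 to 110 mL.min-1.g-1.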

Compound 3, intrinsic clearance in microsomes: 58 mL.min-1.g-1
Beside the measured number, compound 3's estimate is 1.1-fold (0.05 log units) above it; the range from low to high includes it.
By their numbers in this assay, from the lowest: compounds 1 and 3 (each within the scatter of the next); then compound 2.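

In this assay, the loss of a single methyl from isopropyl, leaving ethyl on the same ring carbon, is enough to give a 2.2-fold lower number from compound 2 to compound 3 (0.33 log units; beyond the scatter), so this position responds to a very small trim. Ethyl and methyl, by contrast, are not separated, with a 1.6-fold higher number from compound 1 to compound 3 (0.21 log units; within the scatter), so among these three groups only isopropyl stands apart, and the change in number does not follow group size in even steps. Nothing shown here explains why removal differs among these groups.

The compounds shown leave open what happens with a bare hydrogen at this ring carbon, or with a longer chain such as n-propyl. They also leave open whether a cyclopropyl ring or a hydroxymethyl group would fall with ethyl and methyl or with isopropyl.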